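This account rests on a few compounds, and the source may have more. Where it says the series, first, only, none or still open, it means among the compounds named here.

Of the compounds shown here, two built on the same core have been measured in an assay on isolated protein for inhibition of Caspase-8 (Homo sapiens); on this read-out higher numbers stand for weaker inhibition and lower numbers for stronger inhibition. Compound 1 `O=C(CN1CCSC[C@H](NC(=O)c2ccccc2)C1=O)N[C@H]1CC(=O)OC1O` carries hydrogen on the aromatic carbon where the next compound carries trifluoromethyl, and in this assay compound 1 gives 5200 nM. Compound 2 `O=C(CN1CCSC[C@H](NC(=O)c2cccc(C(F)(F)F)c2)C1=O)N[C@H]1CC(=O)OC1O` has trifluoromethyl in place of that hydrogen. For compound 2 this assay reports only a limit, > 10000 nM, so its exact number is not known. The step from compound 1 to compound 2 is an at least 1.9-fold higher number from compound 1 to compound 2 (0.28 log units; that floor lies within the scatter), a floor that lies within the usual scatter and that rests on (the limit of > 10000 nM in this assay, at which 1 of the 2 values shown sits).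

Compound 3 `O=C(CN1CCSC[C@H](NC(=O)c2ccc3ccccc3c2)C1=O)N[C@H]1CC(=O)OC1O` is not yet measured. It differs from compound 2 by naphthalen-2-yl in place of 3-(trifluoromethyl)phenyl on a carbonyl carbon. No measured step swaps one aromatic group for another, so the single step shown gives no direct guide, and both measured compounds sit in a weak range. The step is therefore expected to be an at least 1.2-fold lower number from compound 2 to compound 3 (0.09 log units; that floor lies within the scatter), that is, no clear change beyond the scatter. For compound 3 the estimate in this assay is 8000 nM, between 2500 nM and 30000 nM, with a fair chance that only a limit is reported again.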

Compound 3, half-maximal inhibitory concentration: 9400 nM
For compound 3 the middle estimate is 1.2-fold (0.07 log units) below the measured one, and the stated range covers the measured number.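

In this assay, among these compounds, the change from phenyl to naphthalen-2-yl on the carbonyl carbon is the first change at this position with a real number at both ends: a 1.8-fold higher number from compound 1 to compound 3 (0.26 log units; within the scatter). A second six-membered aromatic ring of carbon at this place therefore brings no clear change, so this position accepts the larger aromatic group without a shift that stands out from the scatter. The comparison with the trifluoromethyl compound says much less, as an at least 1.0-fold lower number from compound 2 to compound 3 (0.02 log units; that floor lies within the scatter) is only a floor, and compounds 2 and 3 cannot be put in order on that basis: the limit of > 10000 nM in this assay, at which 1 of the 3 values shown sits.

The compounds shown leave open whether a different kind of group on the carbonyl carbon, such as a phenyl ring carrying an amine or a carboxylic acid, or a longer alkyl chain in place of the aromatic ring, would give a number clearly lower than any seen here. On these data alone, they also leave open how far compound 2 really lies from compound 1 and compound 3, since its exact number is unknown.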